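Benzyl Ether Exchange and Expected Tolerated Concentration

This account rests on a few compounds, and the source may have more. Where it says the series, first, only, none or still open, it means among the compounds named here.

Measured compounds:
compound 1 `O=c1c(OCc2cccc(Br)c2)c(-c2ccccc2)oc2cc(O)cc(O)c12` — 15000 nM
compound 2 `COc1cccc(COc2c(-c3ccccc3)oc3cc(O)cc(O)c3c2=O)c1` — 28000 nM

In an ADME assay on Huh-5-2 cells (Homo sapiens) for cytotoxicity, read by WST assay, with a stated time of 3 days (a lower number here means that less compound is tolerated, a higher number that more compound is tolerated), compound 1 gives 15000 nM and compound 2 gives 28000 nM. Compound 2 stands at the end of the two numbers with compound 1 nearest, the step of a 1.9-fold higher number from compound 1 to compound 2 (0.27 log units; within the scatter) being within the scatter, so the two are not distinguished here. Compound 3 `O=c1c(OCc2ccc(Cl)cc2)c(-c2ccccc2)oc2cc(O)cc(O)c12` is not yet measured. It differs from compound 2 by 4-chlorophenyl in place of 3-methoxyphenyl on a saturated chain carbon bound to an oxygen on an aromatic ring. For the measured compounds named here, the only measured step bearing on this is a 1.9-fold higher number from compound 1 to compound 2 (0.27 log units; within the scatter), where a halogen was exchanged for methoxy on that ring; compound 3 returns to a halogen, though on a different position of the ring. Since that step was within the scatter, compound 3 is expected to show no step beyond the scatter, with a value near compound 1 and compound 2, as a 1.6-fold lower number from compound 2 to compound 3 (0.19 log units; within the scatter). Compound 3 is thus estimated at 18000 nM, with a range of 8000 nM to 45000 nM.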

Compound 3, half-maximal cytotoxic concentration: 36000 nM
Beside the measured number, compound 3's estimate is 2.0-fold (0.30 log units) below it; low and high end bracket the measured number.
By their numbers in this assay, from the lowest: compounds 1, 2 and 3 (each within the scatter of the next, the first and the last beyond it).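

In this assay, this place on the saturated chain carbon bound to an oxygen on an aromatic ring now shows its first step beyond the scatter, though a modest one, with 4-chlorophenyl in place of 3-bromophenyl (a 2.4-fold higher number from compound 1 to compound 3 (0.38 log units; beyond the scatter)). The exchange of 3-methoxyphenyl for 4-chlorophenyl stays within the scatter (a 1.3-fold higher number from compound 2 to compound 3 (0.11 log units; within the scatter)), so these two groups are not told apart, and compound 2 cannot be ordered against either neighbour. No measurement offered here accounts for these numbers.

The compounds shown leave open whether the step from compound 1 to compound 3 follows the change of halogen, the change of ring place, or both, which a 3-chlorophenyl or 4-bromophenyl group would help to separate. They also leave open how this assay would respond to an amine or a carboxylic acid on that ring, or to a longer chain at this place.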